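Dimethylphenyl in place of trifluoromethylphenyl on compound 1

A few compounds are considered here, and "the series" means these few. Any claim that something is new, unique, unknown or untested is made for them only; others in the source may bear on it.

Compound 1 `Cc1nc(-c2ccccc2)c(C(=O)N2CCN(c3ccc(C(F)(F)F)cc3)CC2)o1` is recorded in a functional assay on HL-60 cells (Homo sapiens) for inhibition, read by MTT assay, with a stated time of 72 h (a higher number here means a weaker inhibitor, a lower number a stronger inhibitor), only as a limit, > 1000 nM, so no single number places it. Compound 2 `Cc1nc(-c2ccccc2)c(C(=O)N2CCN(c3ccc(C(=O)C(C)C)cc3)CC2)o1` is reported in this assay as "not active" (no number reported). For the measured compounds named here, compound 3 `CCc1nc(-c2ccc(F)cc2)c(C(=O)N2CCN(c3cccc(OC)c3)CC2)o1` gives 411 nM in this assay, the one numerical value among the three. Compound 1 thus sits at the limit of > 1000 nM in this assay, at which 1 of the 3 values shown sits. Compound 4 `Cc1nc(-c2ccccc2)c(C(=O)N2CCN(c3ccc(C)c(C)c3)CC2)o1` differs from compound 1 in one place: 3,4-dimethylphenyl in place of 4-(trifluoromethyl)phenyl on an amine nitrogen in a ring. Going by the values given here, no step between two measured compounds is available to set a scale for this change. With compound 1 known only as a limit, the step is expected to be small in either direction or within the scatter, a step that the limit leaves unreadable from compound 1 to compound 4. Compound 4 is therefore estimated at 2000 nM in this assay, between 500 nM and 8000 nM.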

Compound 4, half-maximal inhibitory concentration: 43 nM
For compound 4 the middle estimate is 47-fold (1.67 log units) above the measured one; measured number outside the range, below it.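

Placing 3,4-dimethylphenyl in place of 4-(trifluoromethyl)phenyl on an amine nitrogen in a ring gives, in this assay, an at least 23-fold lower number from compound 1 to compound 4 (1.36 log units; beyond the scatter). For the compounds shown here, this is the first step, and it shows that the group at this position can move the read-out beyond the scatter. Its true size stays a minimum, because compound 1 is recorded only as a limit: the limit of > 1000 nM in this assay, at which 1 of the 4 values shown sits.

The compounds shown leave open whether a single methyl group would give a similar step. They also leave open how a chlorine atom or an amine in place of the methyl groups would read.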